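The source may hold more compounds than are shown below. What is called first, only, known or untested is meant among the compounds shown, and "the series" means these compounds.

Working notes on the series. Compound 1 `COc1ccc(-c2cc(N3CCC(CNS(N)(=O)=O)CC3)ncn2)cc1` gives 24500 nM in a functional assay on T47D cells (Homo sapiens) for antiproliferative activity; on this read-out higher numbers stand for weaker inhibition of growth and lower numbers for stronger inhibition of growth. Compound 2 `COc1ccccc1-c1cc(N2CCC(CNS(N)(=O)=O)CC2)ncn1` carries 2-methoxyphenyl in place of 4-methoxyphenyl on an aromatic carbon. In this assay compound 2 gives > 100000 nM, which is a limit of the assay and not a number. The step of an at least 4.0-fold higher number from compound 1 to compound 2 (0.61 log units; beyond the scatter) therefore rests on (the limit of > 100000 nM in this assay, at which 1 of the 2 values shown sits), and compound 2 stands at the weak end of the two values shown.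

Compound 3 `NS(=O)(=O)NCC1CCN(c2cc(-c3ccccc3Cl)ncn2)CC1` differs from compound 2 by chloro in place of methoxy on an aromatic carbon. Among the compounds with values here, no measured step bears directly on this exchange: the only measured step, an at least 4.0-fold higher number from compound 1 to compound 2 (0.61 log units; beyond the scatter), sets 2-methoxyphenyl against 4-methoxyphenyl and says nothing about replacing methoxy with chloro. The step from compound 2 to compound 3 is therefore expected to stay within the scatter, that is an at least 1.1-fold lower number from compound 2 to compound 3 (0.04 log units; that floor lies within the scatter). Compound 3 is estimated at 90000 nM in this assay, with a range from 30000 nM to 300000 nM, and a further limit rather than a number is considered likely.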

Compound 3, concentration for 50% growth inhibition: 65500 nM
The estimate for compound 3 lay 1.4-fold (0.14 log units) above the measured number; the measured number falls inside the stated range.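

In this assay, the step of a 2.7-fold higher number from compound 1 to compound 3 (0.43 log units; beyond the scatter) gives the series its first actual number for a group on an aromatic carbon ortho to a large group, and that number is still on the weak side of compound 1. Compound 2 remains at > 100000 nM, which is a limit of the assay and not a number. The step of an at least 1.5-fold lower number from compound 2 to compound 3 (0.18 log units; that floor lies within the scatter) is therefore only a floor, and no order between chloro and methoxy at this place can be read from it: the limit of > 100000 nM in this assay, at which 1 of the 3 values shown sits.

Going by these compounds, the step from compound 1 to compound 3 changes both the group and its place, so the share of each remains open. A 4-chlorophenyl or an unsubstituted phenyl group would be needed to separate them, and a 2-aminophenyl group would extend the reading at this place.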